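What removing one methyl may do to compound 2

This account rests on a few compounds, and the source may have more. Where it says the series, first, only, none or still open, it means among the compounds named here.

Measured in an ADME assay on NIH3T3 cells (Mus musculus) for cytotoxicity, read by MTT assay, with a stated time of 24 h; on this read-out higher numbers stand for weaker inhibition and lower numbers for stronger inhibition:
compound 1 `Cc1ccc(-c2cs/c(=N/NC(=O)CSc3nnnn3-c3ccccc3)n2-c2ccccc2)cc1` gives > 500 ug/mL
compound 2 `Cc1ccc(-c2cs/c(=N/NC(=O)CSc3nncn3C)n2-c2ccccc2)cc1` gives 130 ug/mL
compound 3 `Cc1ccc(-c2cs/c(=N/NC(=O)CSc3nnnn3C)n2-c2ccccc2)cc1` gives 243 ug/mL

The entry for compound 1, > 500 ug/mL, is a limit of the assay and not a number. Only compound 2 and compound 3 carry real numbers, and these two cannot be told apart, with a 1.9-fold higher number from compound 2 to compound 3 (0.27 log units; within the scatter) as the whole gap.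

Compound 4 `Cn1cnnc1SCC(=O)N/N=c1/scc(-c2ccccc2)n1-c1ccccc1` alters compound 2 in one place, with hydrogen in place of methyl on an aromatic carbon, which turns 4-methylphenyl to phenyl. The count of that change is hydrogen in place of methyl on an aromatic carbon in full.

For the measured compounds named here, no measured step touches this group, so the evidence is indirect. All three steps change the group on a sulfur instead. Two of them, an at least 3.8-fold lower number from compound 1 to compound 2 (0.58 log units; beyond the scatter) and an at least 2.0-fold lower number from compound 1 to compound 3 (0.31 log units; beyond the scatter), start from the limit of compound 1 and remove a whole phenyl, a much larger change than one methyl. With so small a change, no shift beyond the scatter is expected, and the estimated step is a 1.1-fold higher number from compound 2 to compound 4 (0.03 log units; within the scatter) in this assay for now. The expected value for compound 4 is 140 ug/mL with an estimated range from 60 ug/mL to 330 ug/mL.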

Compound 4, half-maximal inhibitory concentration: 217 ug/mL
Compound 4: the middle estimate sits 1.6-fold (0.19 log units) below what was measured, within the range that was stated.
By their numbers in this assay, from the lowest: compounds 2, 4 and 3 (each within the scatter of the next). At a limit, above all of these: compound 1.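

For the compounds shown here, this is the first measured step that touches the 4-methylphenyl group rather than the group on the sulfur. In this assay, taking away the methyl on that aromatic carbon gives a 1.7-fold higher number from compound 2 to compound 4 (0.22 log units; within the scatter), so at this place, with the 4-methyl-4H-1,2,4-triazol-3-yl group on the sulfur, the methyl and hydrogen forms cannot be told apart. Unlike the steps from compound 1, this one has real numbers at both ends, and only compound 1 stands at a limit: the limit of > 500 ug/mL in this assay, at which 1 of the 4 values shown sits.

As far as these compounds go, what a larger or charged group, such as an amine or a carboxylic acid, would give at this place on the ring remains open. So does whether the same swap gives so small a step with the 1-methyl-1H-tetrazol-5-yl group on the sulfur.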